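A few compounds are considered here, and "the series" means these few. Any claim that something is new, unique, unknown or untested is made for them only; others in the source may bear on it.

Working notes on the series. Compound 1 `Cc1cc(OCC(=O)Nc2nc(-c3ccc(Br)cc3)cs2)ccc1Cl`, compound 2 `O=C(COc1ccc(F)cc1)Nc1nc(-c2ccc(Br)cc2)cs1` and compound 3 `Cc1ccccc1OCC(=O)Nc1nc(-c2ccc(Br)cc2)cs1` share one core and differ only in the aryl group carried on the oxygen on a saturated carbon. In a functional assay on MDA-MB-468 cells (Homo sapiens) for cytotoxicity, read by trypan blue exclusion, with a stated time of 48 h (on this read-out lower numbers stand for stronger inhibition and higher numbers for weaker inhibition), compound 1 gives 51700 nM, compound 2 gives 51700 nM and compound 3 gives 44500 nM. Compound 3 stands at the lowest of the three numbers, though each step to it is small and inside the scatter: a 1.2-fold lower number from compound 1 to compound 3 (0.07 log units; within the scatter) and a 1.2-fold lower number from compound 2 to compound 3 (0.07 log units; within the scatter); between the other two, no change at the digits printed from compound 1 to compound 2 (within the scatter). Across the three aryl swaps at this oxygen, nothing separates the compounds in this assay.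

Compound 4 `Cc1ccc(OCC(=O)Nc2nc(-c3ccc(Br)cc3)cs2)cc1` is not yet measured. It differs from compound 3 by 4-methylphenyl in place of 2-methylphenyl on an oxygen on a saturated carbon. For the measured compounds named here, no measured step shifts a methyl from one position of the ring to another, so the only steps that bear on the change are the three aryl exchanges at the same oxygen, all of which lie within the scatter. The expected step in this assay is therefore a 1.1-fold higher number from compound 3 to compound 4 (0.02 log units; within the scatter), nothing beyond the scatter in either direction. Compound 4 is estimated in this assay at 47000 nM, with a range from 25000 nM to 90000 nM.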

Compound 4, half-maximal inhibitory concentration: 44500 nM
Compound 4: the middle estimate sits 1.1-fold (0.02 log units) above what was measured; the range from low to high includes it.
By their numbers in this assay, from the lowest: compounds 3, 4, 1 and 2 (each within the scatter of the next).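

The exchange of 2-methylphenyl for 4-methylphenyl on the oxygen on a saturated carbon keeps the same atoms and alters only how they are joined, and in this assay it gives no change at the digits printed from compound 3 to compound 4 (within the scatter), so the place of the single methyl on this ring does not separate the two compounds. The two other new steps extend the same reading to the substituent itself, with methyl in place of fluoro on an aromatic carbon giving a 1.2-fold lower number from compound 2 to compound 4 (0.07 log units; within the scatter) and 4-methylphenyl in place of 4-chloro-3-methylphenyl giving a 1.2-fold lower number from compound 1 to compound 4 (0.07 log units; within the scatter), so all four compounds now lie within the scatter of one another. Nothing further is available to explain this flat result or to show what it reflects in the cells.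

The compounds shown leave open whether any aryl group on this oxygen can move the number beyond the scatter, since they carry only methyl, fluoro and chloro on the ring. A carboxylic acid or a dimethylamino group on that ring, or a longer chain in place of the saturated carbon, remains to be read against this flat set.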